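The compounds below may be only part of what the source reports. "The series", "measured", "known", "first", "only" and "open" are said of these compounds alone.

In an ADME assay on L132 cells (Homo sapiens) for cytotoxicity, read by MTT assay, with a stated time of 48 h (a lower number here means a stronger inhibitor, a higher number a weaker inhibitor), the measured compounds stand as follows.
Compound 1 `C/C(=C\CC/C(C)=C/CC[C@@H]1[C@@]2(C)CCC(=O)C(C)(C)[C@H]2CC[C@@]1(C)O)CC/C=C(\C)C(=O)OCc1cn(-c2ccc(F)cc2)nn1` gives only a limit of the assay, > 150000 nM.
Compound 2 `C/C(=C\CC/C(C)=C/CC[C@@H]1[C@@]2(C)CCC(=O)C(C)(C)[C@H]2CC[C@@]1(C)O)CC/C=C(\C)C(=O)OCc1cn(-c2ccccc2Br)nn1` gives only a limit of the assay, > 150000 nM.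

Compound 2 therefore stands at the limit of > 150000 nM in this assay, at which 2 of the 2 values shown sit. The step that the two limits leave unreadable from compound 1 to compound 2 is not readable in this assay. Compound 3 `C/C(=C\CC/C(C)=C/CC[C@@H]1[C@@]2(C)CCC(=O)C(C)(C)[C@H]2CC[C@@]1(C)O)CC/C=C(\C)C(=O)OCc1cn(-c2ccc(Br)cc2)nn1` differs from compound 2 by 4-bromophenyl in place of 2-bromophenyl on an aromatic nitrogen. No measured step bears on this change, and the one step shown gives no direction. In this assay compound 3 is expected to move by a step that the limit leaves unreadable from compound 2 to compound 3, which is nothing beyond the scatter. Compound 3 is thus estimated at 200000 nM, within 100000 nM to 400000 nM, and is expected to be reported again only as a limit.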

Compound 3, half-maximal inhibitory concentration: > 150000 nM
Compound 3 gave a limit, no number (the forecaster's own chance of this, stated with the estimate: 85%); the middle value lies beyond the limit too.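

For the compounds shown here, compound 1, compound 2 and compound 3 all give only limits in this assay, so no step among them can be read. The compounds shown leave open whether 2-bromophenyl, 4-bromophenyl and 4-fluorophenyl differ at all in cytotoxicity.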